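A few compounds are considered here, and "the series" means these few. Any claim that something is new, unique, unknown or untested is made for them only; others in the source may bear on it.

Compound 1 `CCN(CC)CCCC(C)/N=C(/N)NC(=O)c1cccc(Cl)c1CCc1cc(Br)ccc1OC`: 0.83 nM
Compound 2 `CCN(CC)CCCC(C)/N=C(/N)NC(=O)c1cccc(F)c1OCc1cc(Br)ccc1OC`: 900 nM

Of the compounds shown here, two have been measured in an assay for binding affinity to Melanocortin receptor 4 (Homo sapiens); on this read-out lower numbers stand for stronger inhibition and higher numbers for weaker inhibition. Compound 1 gives 0.83 nM, and compound 2 gives 900 nM. Within the data shown here, compound 2 therefore stands at the higher of the two numbers, its only neighbour being compound 1, which lies far below it, well beyond the scatter. Among the measured compounds shown here, the two structures differ in more than one place, so no single counted step connects them.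

Compound 3 `CCN(CC)CCCC(C)/N=C(/N)NC(=O)c1cccc(F)c1CCc1ccccc1Cl` has not yet been measured. It differs from compound 2 in one place: a group of 9 heavy atoms (8 carbon, 1 chlorine; one six-membered aromatic ring of carbon only) in place of a group of 11 heavy atoms (8 carbon, 2 oxygen, 1 bromine; one six-membered aromatic ring of carbon only), on an aromatic carbon. The change sits on an aromatic carbon ortho to a fluoro group and ortho to a large group. For the measured compounds named here, no step between measured compounds is available, so the expectation rests on the two values alone. The entering group makes compound 3 resemble compound 1 more closely than compound 2 does, while the fluoro group of compound 2 is kept. The step from compound 2 to compound 3 is expected to be a 90-fold lower number from compound 2 to compound 3 (1.95 log units; beyond the scatter), a large move toward stronger binding, beyond the scatter. Compound 3 is therefore estimated to give 10 nM, within a range from 1 nM to 100 nM.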

Compound 3, inhibition constant: 26000 nM
Beside the measured number, compound 3's estimate is 2600-fold (3.41 log units) below it; measured number above the stated range.
By their numbers in this assay, from the lowest: compound 1; then compound 2; then compound 3.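

In this assay, the step of a 29-fold higher number from compound 2 to compound 3 (1.46 log units; beyond the scatter) shows that this aromatic carbon, ortho to a fluoro group and ortho to a large group, is highly sensitive to the group it carries, and that a substituent there can raise the number well beyond the scatter as well as lower it. The 2-(2-chlorophenyl)ethyl group, with its single aromatic ring of carbon only and no hydrogen-bond acceptors, is clearly less well tolerated than the group of 11 heavy atoms with its oxygen and bromine, even though that group already stood at the high end of the earlier pair. No measurement shown here accounts for the size or the direction of this move.

This single exchange alters the link to the aromatic ring and the ring's substituents together, so the compounds shown cannot assign the rise to any one of these features. Also open, as far as these compounds go, is how the number would respond to a 2-phenylethyl group with no chlorine, or to a longer chain, a hydroxyl or a nitrile on this same aromatic carbon.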